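From Isopropyl to 4-Methylphenyl on the Ring Nitrogen

The compounds below may be only part of what the source reports. "The series", "measured", "known", "first", "only" and "open" are said of these compounds alone.

In a functional assay on HeLa cells (Homo sapiens) for antiproliferative activity, read by MTT assay, with a stated time of 72 h (a lower number here means a stronger inhibitor, a higher number a weaker inhibitor), compound 1 (`COc1ncc(-c2ccc3c(c2)N(c2ccc(C)cc2)C(=O)CO3)cc1NS(=O)(=O)c1ccc(F)cc1`) gives 4650 nM and compound 2 (`CC(C)N1C(=O)COc2ccc(-c3cnc(Cl)c(NS(=O)(=O)c4ccc(F)cc4)c3)cc21`) gives 5380 nM so that the two stand level within the scatter. Compound 3 (`Cc1ccc(N2C(=O)COc3ccc(-c4cnc(Cl)c(NS(=O)(=O)c5ccc(F)cc5)c4)cc32)cc1`) keeps the rest of compound 2 but carries 4-methylphenyl in place of isopropyl on an amide-type nitrogen in a ring, a change counted as 4-methylphenyl in place of isopropyl on an amide-type nitrogen in a ring here. Among the compounds with values here, no measured pair isolates this change, so the data give no direct size for it. Within the data shown here, with compound 1 at 4650 nM and compound 2 at 5380 nM as the only guides, no movement beyond the scatter is expected in this assay in either direction. The expected step is a 1.1-fold lower number from compound 2 to compound 3 (0.03 log units; within the scatter) and is estimated to stay within the scatter. For compound 3 the value is estimated at 5000 nM with a range of 1800 nM to 14000 nM before any measurement.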

Compound 3, half-maximal inhibitory concentration: 32300 nM
The estimate for compound 3 lay 6.5-fold (0.81 log units) below the measured number; measured number outside the range, above it.
By their numbers in this assay, from the lowest: compounds 1 and 2 (each within the scatter of the next); then compound 3.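

In this assay, the group on the amide-type nitrogen matters when chloro sits on the aromatic carbon: 4-methylphenyl in place of isopropyl gives a 6.0-fold higher number from compound 2 to compound 3 (0.78 log units; beyond the scatter). With 4-methylphenyl held on that nitrogen, chloro in place of methoxy gives a 6.9-fold higher number from compound 1 to compound 3 (0.84 log units; beyond the scatter), so the level standing of compound 1 and compound 2, which differ in two places, had concealed two steps beyond the scatter. No measurement shown here accounts for either step.

Going by these compounds, it remains open whether the step on the nitrogen comes from the aromatic ring of 4-methylphenyl or from its methyl, and whether methoxy would give the same reading with isopropyl on that nitrogen. On these data alone, how an amine, a carboxylic acid or a longer chain would read on that nitrogen in this assay is also open.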